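The compounds below may be only part of what the source reports. "The series", "measured", "known", "first", "only" and "open" are said of these compounds alone.

Compound 1 `CCCCc1ccc(CN)c(=O)n1Cc1ccc(-c2ccccc2-c2nn[nH]n2)cc1` carries a free amine on the chain that hangs from the shared core, and in a functional assay (aorta) for antagonist activity, with Oryctolagus cuniculus as the target (a lower number here means a stronger inhibitor, a higher number a weaker inhibitor), compound 1 gives 20 nM. Compound 2 `CCCCc1ccc(CNCc2ccccc2)c(=O)n1Cc1ccc(-c2ccccc2-c2nn[nH]n2)cc1` adds a benzyl group to that amine; in this assay compound 2 gives 1 nM, which is a 20-fold lower number from compound 1 to compound 2 (1.30 log units; beyond the scatter). Compound 3 `CCCCc1ccc(CN(CC)S(C)(=O)=O)c(=O)n1Cc1ccc(-c2ccccc2-c2nn[nH]n2)cc1` replaces the amine with an ethyl(methylsulfonyl)amino group; in this assay compound 3 gives 2 nM, which is a 10-fold lower number from compound 1 to compound 3 (1.00 log units; beyond the scatter). Compound 2 therefore has the lowest number of the three, though its gap to compound 3 is a 2.0-fold higher number from compound 2 to compound 3 (0.30 log units; within the scatter).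

Compound 4 `CCCCc1ccc(CN(C)S(C)(=O)=O)c(=O)n1Cc1ccc(-c2ccccc2-c2nn[nH]n2)cc1` has not been measured. Against compound 2 the change is methyl(methylsulfonyl)amino in place of benzylamino on a saturated chain carbon bound to an aromatic carbon. The step that bears on it most is a 2.0-fold higher number from compound 2 to compound 3 (0.30 log units; within the scatter). Compound 3 differs from compound 4 only in the ethyl against the methyl on that sulfonamide. Among the measured compounds shown here, no step between them has been measured, so the reading rests on compound 3, which gives 2 nM in this assay. The expected step is therefore a 2.5-fold higher number from compound 2 to compound 4 (0.40 log units; beyond the scatter), within the scatter. Compound 4 is estimated to give 2.5 nM in this assay, with a likely range from 1 nM to 6 nM.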

Compound 4, half-maximal inhibitory concentration: 0.2 nM
For compound 4 the middle estimate is 13-fold (1.10 log units) above the measured one, and the stated range ends above it.
By their numbers in this assay, from the lowest: compound 4; then compounds 2 and 3 (each within the scatter of the next); then compound 1.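

In this assay, the methylsulfonyl-bearing group on the saturated chain carbon bound to an aromatic carbon now clearly surpasses benzylamino, with a 5.0-fold lower number from compound 2 to compound 4 (0.70 log units; beyond the scatter), whereas compound 3 had stayed within the scatter of compound 2. Among the compounds shown here, the group on the sulfonamide nitrogen also turns out to matter far more than the earlier compounds could reveal: exchanging ethyl for methyl alone gives a 10-fold lower number from compound 3 to compound 4 (1.00 log units; beyond the scatter). Measured against the free amine, the whole change gives a 100-fold lower number from compound 1 to compound 4 (2.00 log units; beyond the scatter), the largest step in this set.

Going by these compounds, it remains open whether a bare hydrogen or a propyl chain on that sulfonamide nitrogen, or an acetyl group in place of methylsulfonyl, would keep this gain. Nothing available here explains why the methyl compound gives a lower number than the ethyl compound.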